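The source may hold more compounds than are shown below. What is called first, only, known or untested is meant among the compounds shown, and "the series" means these compounds.

Measured so far in a functional assay on SGC-7901 cells (Homo sapiens) for antiproliferative activity, read by sulforhodamine B assay, with a stated time of 72 h; on this read-out lower numbers stand for stronger inhibition and higher numbers for weaker inhibition:
compound 1 `COc1ccc(C)cc1NC(=S)N/N=C/c1ccc2ccccc2n1`, > 100000 nM (a limit, not a number)
compound 2 `NC(=S)N/N=C/c1cc2cccnc2s1`, 100000 nM
compound 3 `S=C(NCc1ccccc1)N/N=C/c1ccc2ccccc2n1`, 53700 nM

Compound 1 reaches only the limit of this assay: the limit of > 100000 nM in this assay, at which 1 of the 3 values shown sits. Of the two numbers, compound 3 gives the lower one, but compound 2 sits within the scatter of it, so no order between the two is claimed. Compound 4 `S=C(N/N=C/c1ccc2ccccc2n1)Nc1ccccc1` is not yet measured; it differs from compound 3 by phenyl in place of benzyl on an amide-type nitrogen. Among the measured compounds shown here, no measured step in this assay corresponds to this change, so its size is open. Since compound 1, which also carries an aryl group on this nitrogen, gives > 100000 nM in this assay, a weaker result is expected for compound 4 rather than a stronger one. For compound 4 the estimate is 80000 nM, between 30000 nM and 150000 nM, a step of a 1.5-fold higher number from compound 3 to compound 4 (0.17 log units; within the scatter) expected in this assay.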

Compound 4, half-maximal inhibitory concentration: 26500 nM
Compound 4: middle estimate off by 3.0-fold (0.48 log units), on the high side, and the stated range ends above it.
By their numbers in this assay, from the lowest: compound 4; then compounds 3 and 2 (each within the scatter of the next).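

Phenyl in place of benzyl on the amide-type nitrogen is the one measured step here: in this assay it gives a 2.0-fold lower number from compound 3 to compound 4 (0.31 log units; beyond the scatter), so this position responds to the change, though modestly. An aryl group directly on this nitrogen therefore does not by itself abolish activity. Compound 1, which also carries an aryl group here, stays at a limit, not a number: the limit of > 100000 nM in this assay, at which 1 of the 4 values shown sits.

Whether the methoxy and methyl groups of compound 1 account for that limit remains open. So does the effect of a longer chain such as phenethyl, or of a simple alkyl group, on this nitrogen.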